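The source may hold more compounds than are shown below. What is called first, only, known or untested is meant among the compounds shown, and "the series" means these compounds.

Measured so far:
compound 1, `Cc1c(OCCCCOc2ccc(C(=O)O)cc2Cl)ccc(C(=O)CC2CCCC2)c1O`: > 10000 nM
compound 2, `CCC(=O)c1ccc(OCCCCOc2ccc(F)c(C(=O)O)c2)c(C)c1O`: "not determined" (no result reported)

Two compounds have been through an assay on HEK293 cells for positive allosteric modulation of metabotropic glutamate receptor 3 (Rattus norvegicus), read by thallium flux, with a stated time of 2.5 min (a lower number here means that less compound is needed, a higher number that more compound is needed for the effect), so far. Compound 1 has the structure `Cc1c(OCCCCOc2ccc(C(=O)O)cc2Cl)ccc(C(=O)CC2CCCC2)c1O`. In this assay compound 1 gives only a limit, > 10000 nM, not a number. Compound 2 has the structure `CCC(=O)c1ccc(OCCCCOc2ccc(F)c(C(=O)O)c2)c(C)c1O`. In this assay compound 2 gives "not determined" (no result reported), so there is no number for it either. Among the compounds with values here, compound 2 therefore stands nowhere on a scale of numbers; the only other value shown is the limit of > 10000 nM in this assay, at which 1 of the 2 values shown sits, which marks the edge of what this assay can report.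

Compound 3, `CCCC(=O)c1ccc(OCCCCOc2ccc(F)c(C(=O)O)c2)c(C)c1O`, has not yet been measured. It differs from compound 2 in one place: methyl in place of hydrogen on a saturated chain carbon, two bonds along the chain from a carbonyl carbon. Within the data shown here, no step between measured compounds is known here, so there is no measured change of this kind to lean on. Such a small addition to a saturated chain is expected to move the read-out by no more than the usual scatter, in no particular direction. Among the measured compounds shown here, with the only firm value in this assay being the limit of compound 1, compound 3 is estimated at 8000 nM, within a range of 1500 nM to 30000 nM, and a report of only a limit is quite possible.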

Compound 3, half-maximal effective concentration: 438 nM
Estimate against measurement, compound 3: 18-fold (1.26 log units) above; the measured number lies below the stated range.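

No step can be read from these results: compound 2 has no reported result, and compound 1 differs from compound 3 in more than one place. Nothing shown bears on the new result. The compounds shown leave open whether the propylcarbonyl group has any bearing on the value of compound 3, 438 nM, in this assay.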